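Extending the ring nitrogen's methyl to ethyl in compound 1

A few compounds are considered here, and "the series" means these few. Any claim that something is new, unique, unknown or untested is made for them only; others in the source may bear on it.

Compound 1 `Cc1cc(-n2cc(C(=O)Nc3cc(F)cc(F)c3)c(=O)c3ccc(N(C)C)nc32)ccc1OCCCCCCC[N+]1(C)CCCC1`: 35.9%
Compound 2 `CN(C)c1ccc2c(=O)c(C(=O)Nc3cc(F)cc(F)c3)cn(-c3ccc(OCCCCCCC[N+]4(C)CCCC4)c(Cl)c3)c2n1`: 2.59%
Compound 3 `CC[N+]1(CCCCCCCOc2cc(C)cc(-n3cc(C(=O)Nc4cc(F)cc(F)c4)c(=O)c4ccc(N(C)C)nc43)c2)CCCCC1`: 86.6%

Of the compounds shown here, three sharing one core have been tested in an assay on LX2 cells for inhibition of COL1A1 promoter (Homo sapiens), read by a luciferase reporter, with a stated time of 24 h, tested at 50 uM; on this read-out lower numbers stand for a weaker effect and higher numbers for a stronger effect at the one concentration tested. Compound 1 stands second highest of the three; compound 3 lies well above it, and compound 2 well below it. Within the data shown here, the one single-point step recorded is a number 33.3 percentage points lower from compound 1 to compound 2 (beyond the scatter), a large loss.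

Compound 4 `CC[N+]1(CCCCCCCOc2ccc(-n3cc(C(=O)Nc4cc(F)cc(F)c4)c(=O)c4ccc(N(C)C)nc43)cc2C)CCCC1` is to be measured in this assay. It differs from compound 1 by methyl in place of hydrogen on a saturated chain carbon bound to an amine nitrogen in a ring. Among the measured compounds shown here, no measured pair differs in that place alone. Compound 3 does carry ethyl on the ring nitrogen, but it also has a larger ring and a different arrangement of groups on the aryl ring, so its gap to compound 1 cannot be credited to the ethyl alone. For the measured compounds named here, the only measured step concerns a change on the aromatic ring, not the charged ring nitrogen, so it offers little guidance here.

The change is small in atom count and leaves charge and hydrogen-bonding features unaltered. A modest rise is expected, with wide uncertainty: compound 4 is estimated at 45%, from 20% to 75%, meaning an expected step of a number 9.1 percentage points higher from compound 1 to compound 4 (within the scatter).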

Compound 4, a percentage reported as inhibition, at one concentration (the size of the read-out at that concentration, not a potency): 82.5%
Compound 4: middle estimate off by 37.5 percentage points, on the low side, outside the stated range (above it).
By their numbers in this assay, from the lowest: compound 2; then compound 1; then compounds 4 and 3 (each within the scatter of the next).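

Among these compounds, until now no measured pair isolated this position, and the step of a number 46.6 percentage points higher from compound 1 to compound 4 (beyond the scatter) in this assay shows that it strongly affects the read-out. The change, methyl in place of hydrogen on a saturated chain carbon bound to an amine nitrogen in a ring, can equally be read as methyl to ethyl and adds only 1 heavy atom (1 carbon), yet this large step runs in the opposite direction to the other single-place step, a number 33.3 percentage points lower from compound 1 to compound 2 (beyond the scatter), which is chloro in place of methyl on an aromatic carbon. Nothing shown here measures why the small addition of carbon raises the number.

Still open, from the compounds shown here alone, is whether the rise continues with a longer chain at this place, such as propyl or butyl, or holds with a branched group such as isopropyl or a benzyl group. Also open, going by these compounds, is whether methyl to ethyl would bring a similar rise with chloro on the aromatic carbon, as carried by compound 2, and, with only one concentration tested, how these numbers relate to potency.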